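A few compounds are considered here, and "the series" means these few. Any claim that something is new, unique, unknown or untested is made for them only; others in the source may bear on it.

Measured so far in a functional assay on HL-60 cells (Homo sapiens) for cytotoxicity, read by CCK-8 assay, with a stated time of 24 h; on this read-out higher numbers stand for weaker inhibition and lower numbers for stronger inhibition:
- compound 1 `C=CC(=O)N1C(=O)CC(c2ccc([N+](=O)[O-])cc2)Sc2ccccc21`, 107000 nM
- compound 2 `C=CC(=O)N1C(=O)CC(c2ccccc2Cl)Sc2ccccc21`, 91400 nM
- compound 3 `C=CC(=O)N1C(=O)CCSc2ccccc21`, 44800 nM

Compound 2 stands second highest of the three numbers. Its value and that of compound 1 lie within the scatter of each other, so those two read alike. For the measured compounds named here, the one measured step that touches compound 2 is a 2.0-fold lower number from compound 2 to compound 3 (0.31 log units; beyond the scatter), a modest move.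

Compound 4 `C=CC(=O)N1C(=O)CC(c2ccccc2)Sc2ccccc21` differs from compound 2 by hydrogen in place of chloro on an aromatic carbon. Going by the values given here, this is a smaller change than the one from compound 2 to compound 3, and the pair of compound 1 and compound 2 shows that a different group on the aryl ring left the number within the scatter. The step of a 1.1-fold lower number from compound 2 to compound 4 (0.06 log units; within the scatter) is therefore expected to stay within the scatter. For compound 4 the estimate in this assay is 80000 nM, with a range from 40000 nM to 160000 nM.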

Compound 4, half-maximal inhibitory concentration: 97400 nM
Estimate against measurement, compound 4: 1.2-fold (0.09 log units) below, within the range that was stated.
By their numbers in this assay, from the lowest: compound 3; then compounds 2, 4 and 1 (each within the scatter of the next).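

In this assay taking off the chloro gives a 1.1-fold higher number from compound 2 to compound 4 (0.03 log units; within the scatter) and taking off the nitro gives a 1.1-fold lower number from compound 1 to compound 4 (0.04 log units; within the scatter) so the plain phenyl reads alike with both substituted rings. For the compounds shown here, the one step beyond the scatter here is the phenyl itself on the saturated ring carbon, with a 2.2-fold higher number from compound 3 to compound 4 (0.34 log units; beyond the scatter) as a modest move that compound 2 and compound 1 share in their readings. Nothing available explains this behaviour.

Still open, as far as these compounds go, is whether an amine or a carboxylic acid on the aromatic ring would move the number away from compound 4. A longer chain in place of the phenyl is equally untested in the compounds shown.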